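This account rests on a few compounds, and the source may have more. Where it says the series, first, only, none or still open, it means among the compounds named here.

- compound 1 `CCC1=C(C(=O)OCC2CCCCC2)C(c2cccc([N+](=O)[O-])c2)NC(=O)N1`: > 10000 nM (limit)
- compound 2 `CCC1=C(C(=O)OCC2CCCCC2)C(c2ccc(N(C)C)cc2)NC(=O)N1`: > 10000 nM (limit)
- compound 3 `CCC1=C(C(=O)OCC2CCCCC2)C(c2ccc(C(=O)O)cc2)NC(=O)N1`: not yet measured

In an ADME assay on CEMx174 cells (Homo sapiens) for cytotoxicity (a lower number here means that less compound is tolerated, a higher number that more compound is tolerated), compound 2 stands at > 10000 nM as a limit and not as a number. Compound 1 reads > 10000 nM as a limit too. The picture so far is the limit of > 10000 nM in this assay, at which 2 of the 2 values shown sit, and compound 2 has no number to be ranked by.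

The next change is carboxy in place of dimethylamino on an aromatic carbon (carboxy in place of dimethylamino on an aromatic carbon, para to a large group). Going by the values given here, the one measured step bearing on it is a step that the two limits leave unreadable from compound 1 to compound 2 and it offers no size to carry over. Among the compounds with values here, with a step that the two limits leave unreadable from compound 1 to compound 2 as the only guide, no step beyond the scatter is expected in this assay in either direction, and another limit is the likeliest report. The step expected is a step that the limit leaves unreadable from compound 2 to compound 3 and it remains an estimate. For compound 3 the expected value is 15000 nM with 7000 nM to 40000 nM as the estimated range.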

Compound 3, half-maximal cytotoxic concentration: > 10000 nM
Compound 3: no number, only a limit (the forecaster's own chance of this, stated with the estimate: 85%); the middle value does not contradict the limit.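

Compound 3, like compound 1 and compound 2, gives only a limit and not a number in this assay, so no step among these three compounds can be read: the limit of > 10000 nM in this assay, at which 3 of the 3 values shown sit.

The compounds shown leave open where each one's half-maximal cytotoxic concentration actually lies and whether these changes differ at all.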